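Removing one chloro from the aryl ketone of compound 1

The compounds below may be only part of what the source reports. "The series", "measured", "known", "first", "only" and "open" are said of these compounds alone.

Compound 1 `COc1ccc(/C=C/c2cc(OC)cc(OC)c2/C=C/C(=O)c2ccc(Cl)c(Cl)c2)cc1` is the weaker of the two compounds measured in a functional assay on A549 cells (Homo sapiens) for antiproliferative activity, read by MTT assay, with a stated time of 48 h; on this read-out lower numbers stand for stronger inhibition and higher numbers for weaker inhibition: compound 1 gives 5.9 ug/mL, the highest of the two numbers. Within the data shown here, its only neighbour, compound 2 `COc1ccc(/C=C/c2cc(OC)cc(OC)c2/C=C/C(=O)c2ccc(C)c(C)c2)cc1`, differs in the aryl group on the carbonyl carbon, 3,4-dimethylphenyl in place of 3,4-dichlorophenyl, and compound 2 gives 0.1 ug/mL. The step is large: a 59-fold lower number from compound 1 to compound 2 (1.77 log units; beyond the scatter).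

Compound 3 `COc1ccc(/C=C/c2cc(OC)cc(OC)c2/C=C/C(=O)c2ccc(Cl)cc2)cc1` is not yet measured. It keeps the shared core of compound 1 and alters the same aryl group by a single atom: hydrogen in place of chloro on an aromatic carbon, so that 3,4-dichlorophenyl becomes 4-chlorophenyl. Among the measured compounds shown here, the only measured step that touches this aryl group, a 59-fold lower number from compound 1 to compound 2 (1.77 log units; beyond the scatter), exchanges both chloro groups for methyl, a different change; it shows that this aryl group can move the number a great deal, but it does not show what removing one chloro alone does. A step in the same direction is expected, though much smaller and possibly within the scatter, a 2.0-fold lower number from compound 1 to compound 3 (0.29 log units; within the scatter). Compound 3 is estimated at 3 ug/mL, with a range of 0.8 ug/mL to 12 ug/mL.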

Compound 3, half-maximal inhibitory concentration: 6.4 ug/mL
For compound 3 the middle estimate is 2.1-fold (0.33 log units) below the measured one; the measured number falls inside the stated range.
By their numbers in this assay, from the lowest: compound 2; then compounds 1 and 3 (each within the scatter of the next).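

In this assay, going from 3,4-dichlorophenyl to 4-chlorophenyl gives a 1.1-fold higher number from compound 1 to compound 3 (0.04 log units; within the scatter), so exchanging this chloro for hydrogen leaves the number within the scatter. The large gap to the dimethyl-substituted aryl group remains with only one chloro present, at a 64-fold higher number from compound 2 to compound 3 (1.81 log units; beyond the scatter), so compound 1 and compound 3 both stand far from compound 2. The large step seen earlier therefore does not depend on this one chloro, and nothing at hand gives a reason for the pattern.

Still open, on these data alone, is which methyl of compound 2 carries its low number: a 4-methylphenyl and a 3-methylphenyl on the carbonyl carbon would separate the two, and would show whether the pair is needed. Also open, as far as these compounds go, are the effect of removing the remaining chloro, which 3-chlorophenyl and an unsubstituted phenyl would address, and how groups of another kind, such as a dimethylamino group or a carboxylic acid on this aryl ring, would compare with methyl and chloro.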